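Compound 3 gives up its 4-acetylphenyl group

The source may report more compounds than this note shows. Statements on the series, on what has been measured and on what is new or still open speak of the compounds shown alone.

Measured in a functional assay on HUVEC cells (Homo sapiens) for inhibition (a higher number here means a weaker inhibitor, a lower number a stronger inhibitor), so far
compound 1 `CN(c1ccc(NC(=O)Nc2ccccc2)cc1)c1ccnc(Nc2cccc(S(N)(=O)=O)c2)n1` gives 2 nM
compound 2 `CN(c1ccc(NC(=O)Nc2cc(C(F)(F)F)ccc2F)cc1)c1ccnc(Nc2cccc(S(N)(=O)=O)c2)n1` gives 10 nM
compound 3 `CC(=O)c1ccc(NC(=O)Nc2ccc(N(C)c3ccnc(Nc4cccc(CS(C)(=O)=O)c4)n3)cc2)cc1` gives 2 nM

Compound 3, at 2 nM in this assay, stands level with compound 1, at 2 nM and shares the lowest number of the three with it. Compound 2 lies higher at 10 nM in the same test.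

Compound 4 `CN(C)CCNC(=O)Nc1ccc(N(C)c2ccnc(Nc3cccc(CS(C)(=O)=O)c3)n2)cc1` has not yet been measured. Its difference from compound 3 is this: 2-(dimethylamino)ethyl in place of 4-acetylphenyl on an amide-type nitrogen. A single measured step bears on the change, and only loosely. With 2-fluoro-5-(trifluoromethyl)phenyl in place of phenyl on an amide-type nitrogen, the data show a 5.0-fold higher number from compound 1 to compound 2 (0.70 log units; beyond the scatter), which is beyond the scatter. Going by the values given here, that step keeps an aromatic ring at this place, and no measured compound lacks one there, so the change to compound 4 goes beyond anything tested. A larger move towards a higher number is therefore expected, though on thin evidence. The expected step is a 75-fold higher number from compound 3 to compound 4 (1.88 log units; beyond the scatter) as an estimate. Compound 4 is estimated at 150 nM with an expected range from 20 nM to 1000 nM in this assay once measured.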

Compound 4, half-maximal inhibitory concentration: 530 nM
The estimate for compound 4 lay 3.5-fold (0.55 log units) below the measured number; the measured number falls inside the stated range.
By their numbers in this assay, from the lowest: compounds 1 and 3 (each within the scatter of the next); then compound 2; then compound 4.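

In this assay, going by these compounds alone, the change from 4-acetylphenyl to 2-(dimethylamino)ethyl on the amide-type nitrogen gives a 270-fold higher number from compound 3 to compound 4 (2.42 log units; beyond the scatter) and is the first measured change at this place to remove the aromatic ring. Within the data shown here, the only earlier step here, a 5.0-fold higher number from compound 1 to compound 2 (0.70 log units; beyond the scatter), kept a ring and was modest, whereas this large step shows that the number at this position can rise much further when the ring is replaced by this chain. Nothing in the data given accounts for the rise, so no cause can be assigned.

Going by these compounds, it remains open whether the loss of the ring or the entry of the dimethylamino group drives the step. A plain ethyl chain, a cyclohexyl group or a benzyl group at this place would help separate the two.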